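A few compounds are considered here, and "the series" means these few. Any claim that something is new, unique, unknown or untested is made for them only; others in the source may bear on it.

Compound 1, `O=C1O/C(=C\Cn2cc(-c3cc(F)cc(F)c3)nn2)C(OCc2ccccc2)=C1OCc1ccccc1`: > 100000 nM
Compound 2, `COc1ccccc1-c1cn(C/C=C2\OC(=O)C(OCc3ccccc3)=C2OCc2ccccc2)nn1`: > 100000 nM

In a functional assay on HCT-116 cells (Homo sapiens) for antiproliferative activity, read by MTT assay, with a stated time of 72 h (a lower number here means a stronger inhibitor, a higher number a weaker inhibitor), compound 1 gives > 100000 nM, which is a limit of the assay rather than a number. Compound 2 gives in this assay > 100000 nM, again a limit and not a number. Within the data shown here, both values therefore sit at the same limit (the limit of > 100000 nM in this assay, at which 2 of the 2 values shown sit), so compound 2 stands exactly where compound 1 stands, and the one measured step, a step that the two limits leave unreadable from compound 1 to compound 2, cannot be read in size or direction.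

Compound 3 `O=C1O/C(=C\Cn2cc(-c3cccc(O)c3)nn2)C(OCc2ccccc2)=C1OCc1ccccc1` is built from compound 2 by the change (3-hydroxyphenyl in place of 2-methoxyphenyl on an aromatic carbon). Among the measured compounds shown here, no measured step bears on this change in a readable way: the only step, a step that the two limits leave unreadable from compound 1 to compound 2, is hidden by the limits. With nothing to point to a gain, compound 3 is expected to remain at the limit, with an estimate of 200000 nM in this assay, ranging from 40000 nM to 1000000 nM. The estimated step from compound 2 to compound 3 is a step that the limit leaves unreadable from compound 2 to compound 3.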

Compound 3, half-maximal inhibitory concentration: 63600 nM
Estimate against measurement, compound 3: 3.1-fold (0.50 log units) above; the range from low to high includes it.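

At this position on the five-membered aromatic ring, 3-hydroxyphenyl is the first group shown to give a measured number rather than a limit in this assay. Each comparison has a limit on one side and gives only a floor, so neither proves a real gain: the change gives an at least 1.5-fold lower number from compound 2 to compound 3 (0.19 log units; that floor lies within the scatter), and it gives an at least 1.5-fold lower number from compound 1 to compound 3 (0.19 log units; that floor lies within the scatter). The two earlier compounds remain at the limit, so the number for compound 3 stands alone in this small set: the limit of > 100000 nM in this assay, at which 2 of the 3 values shown sit.

The change from 2-methoxyphenyl to 3-hydroxyphenyl alters both the oxygen-bearing group and its place on the phenyl ring, and the compounds shown do not separate the two. They also leave open how a 3-methoxyphenyl group, or a phenyl ring bearing an amine or a carboxylic acid, would read in this assay.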